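Amide in Place of Amine on the Shared Core

The source may report more compounds than this note shows. Statements on the series, on what has been measured and on what is new or still open speak of the compounds shown alone.

Measured so far: compound 1 `NC/C=C\CN(Cc1nc2ccccc2[nH]1)C1CCCc2cccnc21`, 77 nM; compound 2 `NCCN(Cc1nc2ccccc2[nH]1)C1CCCc2cccnc21`, 1370 nM; compound 3 `NCCCCCN(Cc1nc2ccccc2[nH]1)C1CCCc2cccnc21`, 514 nM.

In a functional assay on CEM-CCRF cells for antagonist activity at C-X-C chemokine receptor type 4 (Homo sapiens), read by calcium flux (a lower number here means a stronger inhibitor, a higher number a weaker inhibitor), compound 2 gives the highest number of the three, with compound 3 nearest and compound 1 furthest from it. Compound 4 `NCCCC(=O)N(Cc1nc2ccccc2[nH]1)C1CCCc2cccnc21` is not yet measured; it differs from compound 2 by (3-aminopropyl)carbonyl in place of 2-aminoethyl on an amine nitrogen. Among the compounds with values here, two measured steps touch this change. Lengthening the chain on the same side, a 2.7-fold lower number from compound 2 to compound 3 (0.43 log units; beyond the scatter), lowered the number, and the shift from the unsaturated chain to the short one, an 18-fold higher number from compound 1 to compound 2 (1.25 log units; beyond the scatter), raised it strongly. Within the data shown here, no measured compound carries a carbonyl on that amine nitrogen, so the effect of that part of the change is uncovered. As far as these compounds go, because the chain lengthening in a 2.7-fold lower number from compound 2 to compound 3 (0.43 log units; beyond the scatter) helped, while the carbonyl is unknown, a step for compound 4 of a 1.5-fold lower number from compound 2 to compound 4 (0.18 log units; within the scatter) is expected, with wide uncertainty. Compound 4 is therefore estimated at 900 nM, in the range 150 nM to 6000 nM.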

Compound 4, half-maximal inhibitory concentration: 3200 nM
Compound 4: the middle estimate sits 3.6-fold (0.55 log units) below what was measured; the measured number falls inside the stated range.
By their numbers in this assay, from the lowest: compound 1; then compound 3; then compound 2; then compound 4.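

In this assay, a carbonyl on the amine nitrogen gives the highest number of the four compounds: (3-aminopropyl)carbonyl in place of 2-aminoethyl brings a 2.3-fold higher number from compound 2 to compound 4 (0.37 log units; beyond the scatter), whereas the earlier lengthening of the saturated chain had lowered the number. The same group in place of 5-aminopentyl brings a 6.2-fold higher number from compound 3 to compound 4 (0.79 log units; beyond the scatter), and in place of 4-aminobut-2-en-1-yl it brings a 42-fold higher number from compound 1 to compound 4 (1.62 log units; beyond the scatter), so neither the longer saturated chain nor the unsaturated chain is matched by this amide. Nothing at hand bears on why the number rises with this change.

As far as these compounds go, how a 4-aminobutyl chain on that nitrogen would compare remains open, and with it how much of the step belongs to the carbonyl alone. Also open, from the compounds shown here alone, is whether a longer chain behind the carbonyl, such as (5-aminopentyl)carbonyl, would lower the number as it did on the amine.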